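Replacing the 3,4-dinitrophenyl group of compound 1

The compounds below may be only part of what the source reports. "The series", "measured", "known", "first", "only" and "open" are said of these compounds alone.

- compound 1 `Cc1cc(C)cc(NC(=O)NCCNS(=O)(=O)c2ccc(-c3ccccc3Oc3ccc([N+](=O)[O-])c([N+](=O)[O-])c3)s2)c1` gives 3600 nM
- compound 2 `O=C(NCCNS(=O)(=O)c1ccc(-c2ccccc2Oc2ccc([N+](=O)[O-])c([N+](=O)[O-])c2)s1)Nc1ccc([N+](=O)[O-])cc1` gives 3000 nM

Among the measured compounds shown here, in a functional assay on RS4-11 cells (Homo sapiens) for inhibition, read by CCK-8 assay, with a stated time of 48 h (on this read-out lower numbers stand for stronger inhibition and higher numbers for weaker inhibition), compound 1 gives 3600 nM, the higher of only two numbers, yet it cannot be told apart from compound 2. For the measured compounds named here, the one measured step is a 1.2-fold lower number from compound 1 to compound 2 (0.08 log units; within the scatter). That step swaps a group on an amide-type nitrogen, so it bears only indirectly on the next change. In compound 3 `Cc1cc(C)cc(NC(=O)NCCNS(=O)(=O)c2ccc(-c3ccccc3Oc3ccc(N)cc3)s2)c1`, 4-aminophenyl takes the place of 3,4-dinitrophenyl on an oxygen on an aromatic ring (4-aminophenyl in place of 3,4-dinitrophenyl on an oxygen on an aromatic ring). Going by the values given here, no measured step covers this swap, so the direction remains open and the range stays wide. The expected step in this assay is a 1.3-fold higher number from compound 1 to compound 3 (0.10 log units; within the scatter), with nothing beyond the scatter expected. For compound 3 the estimated value is 4500 nM, expected to lie between 1500 nM and 15000 nM.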

Compound 3, half-maximal inhibitory concentration: > 20000 nM
Compound 3: no number, only a limit (the forecaster's own chance of this, stated with the estimate: 15%); middle value at least 4.4-fold (0.64 log units) away from the limit.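

In this assay, among the compounds shown here, the group on this oxygen clearly matters: 4-aminophenyl in place of 3,4-dinitrophenyl gives an at least 5.5-fold higher number from compound 1 to compound 3 (0.74 log units; beyond the scatter), whereas the only earlier step, made on an amide-type nitrogen, stayed within the scatter. The reading for compound 3 is a limit, not a number: the limit of > 20000 nM in this assay, at which 1 of the 3 values shown sits.

The compounds shown cannot separate the loss of the two nitro groups from the arrival of the amine. From the compounds shown here alone, how a plain phenyl or a methoxyphenyl on the same oxygen would read also remains open.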